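A few compounds are considered here, and "the series" means these few. Any claim that something is new, unique, unknown or untested is made for them only; others in the source may bear on it.

Measured compounds:
- compound 1, `COc1ccc(CS(=O)(=O)/C=C/c2c(OC)cccc2OC)cc1[N+](=O)[O-]`: 20000 nM
- compound 2, `COc1ccc(CS(=O)(=O)/C=C/c2c(OC)cccc2OC)cc1N`: 50 nM

In a functional assay on DU-145 cells (Homo sapiens) for cytotoxicity, read by trypan blue exclusion, with a stated time of 96 h (a higher number here means a weaker inhibitor, a lower number a stronger inhibitor), compound 2 stands lowest of the two numbers, its nearest neighbour being compound 1 at 20000 nM; the step of a 400-fold lower number from compound 1 to compound 2 (2.60 log units; beyond the scatter) is large. Compound 3, `COc1ccc(CS(=O)(=O)/C=C/c2c(OC)cc(O)cc2OC)cc1N`, is not yet measured. It differs from compound 2 by hydroxy in place of hydrogen on an aromatic carbon. Going by the values given here, no measured step touches this position; the one step seen concerns the amino group on the other ring. With nothing to set the size of the change, compound 3 is expected to give 40 nM (15 nM to 120 nM). The step of a 1.3-fold lower number from compound 2 to compound 3 (0.10 log units; within the scatter) is thus expected to stay within the scatter.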

Compound 3, half-maximal inhibitory concentration: 200 nM
The estimate for compound 3 lay 5.0-fold (0.70 log units) below the measured number, outside the stated range (above it).
By their numbers in this assay, from the lowest: compound 2; then compound 3; then compound 1.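

In this assay, hydroxy in place of hydrogen on the aromatic carbon meta to two methoxy groups gives a 4.0-fold higher number from compound 2 to compound 3 (0.60 log units; beyond the scatter) in the amino series. The earlier step concerned only the amino group on the other ring; this one shows that the read-out also responds to a change at this position, and in the weakening direction. Nothing available here bears on the reason for this shift. As far as these compounds go, whether an amine, a carboxylic acid or a longer ether chain at this carbon would behave like hydroxy remains open, as does whether the hydroxy step would hold with nitro in place of amino.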